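The source may hold more compounds than are shown below. What is called first, only, known or untested is meant among the compounds shown, and "the series" means these compounds.

Measured in a functional assay on EJ cells (Homo sapiens) for cytotoxicity, read by MTT assay, with a stated time of 48 h; a lower number here means a stronger inhibitor, a higher number a weaker inhibitor:
- Compound 1 `CC(C)=CCC/C(C)=C/CC/C(C)=C/CSc1ccccc1C(=O)NCCN`: > 50000 nM (a limit of the assay)
- Compound 2 `CC(C)=CCC/C(C)=C/CC/C(C)=C/CSc1ccccc1C(=O)NCCCCCN`: 9850 nM
- Compound 3 `CC(C)=CCC/C(C)=C/CC/C(C)=C/CSc1ccccc1C(=O)NCCCCCCN`: 10100 nM

Compound 3 has one numerical neighbour, and the two cannot be told apart: a 1.0-fold higher number from compound 2 to compound 3 (0.01 log units; within the scatter). Going by the values given here, the only other compound, compound 1, gives a limit and not a number.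

Compound 4 `CC(C)=CCC/C(C)=C/CC/C(C)=C/CSc1ccccc1C(=O)NCCOCCN` carries 2-aminoethoxy in place of 4-aminobutyl on a saturated chain carbon, two bonds along the chain from an amide-type nitrogen. Among the compounds with values here, no measured compound has this group, so the swap itself is untested.

The nearest evidence comes from changes to the same chain. Two steps lie beyond the scatter, an at least 5.0-fold lower number from compound 1 to compound 2 (0.70 log units; beyond the scatter) and an at least 4.9-fold lower number from compound 1 to compound 3 (0.69 log units; beyond the scatter), but both start from a limit. The step between the two longer chains shows no change. A small step in this assay is therefore expected, if anything toward a higher number. The expected step is a 1.6-fold higher number from compound 3 to compound 4 (0.20 log units; within the scatter). For compound 4 the estimated value is 16000 nM, with an expected range from 7000 nM to 45000 nM.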

Compound 4, half-maximal inhibitory concentration: 6130 nM
Beside the measured number, compound 4's estimate is 2.6-fold (0.42 log units) above it; measured number below the stated range.
By their numbers in this assay, from the lowest: compounds 4, 2 and 3 (each within the scatter of the next). At a limit, above all of these: compound 1.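

In this assay, the swap to 2-aminoethoxy gives a 1.6-fold lower number from compound 3 to compound 4 (0.22 log units; within the scatter) and, against the 3-aminopropyl chain, a 1.6-fold lower number from compound 2 to compound 4 (0.21 log units; within the scatter). An oxygen in the chain at this place, on a saturated chain carbon, two bonds along the chain from an amide-type nitrogen, therefore leaves the number indistinguishable from those of the all-carbon chains of compound 2 and compound 3, which was not visible from those chains alone. The remaining step, an at least 8.1-fold lower number from compound 1 to compound 4 (0.91 log units; beyond the scatter), starts from compound 1, whose value is a limit and not a number: the limit of > 50000 nM in this assay, at which 1 of the 4 values shown sits.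

The compounds shown leave open whether a longer chain with two ether oxygens would move the number beyond the scatter. They also leave open what a tertiary amine or a carboxylic acid at the chain end would do in this assay.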